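Swapping the Sulfonyl Aryl Group in Compound 1

The compounds below may be only part of what the source reports. "The series", "measured", "known", "first", "only" and "open" are said of these compounds alone.

Measured compounds:
- compound 1, `O=C(NCc1ccc(CNS(=O)(=O)c2ccc([N+](=O)[O-])cc2)cc1)c1cccnc1`, 100 nM
- compound 2, `COc1ccccc1C(=O)NCc1ccc(CNS(=O)(=O)c2ccccc2F)cc1`, 1 nM
- compound 3, `COc1ccccc1C(=O)NCc1ccc(CNS(=O)(=O)c2ccc([N+](=O)[O-])cc2)cc1`, 100 nM

In an assay on MDA-MB-231 cells for displacement of a labelled ligand from C-X-C chemokine receptor type 4 (Homo sapiens), read by fluorescence and microscopy, with stated times of 10 min and 30 min (a lower number here means that less compound is needed, a higher number that more compound is needed for the effect), compound 1 stands level with compound 3 at the digits shown, the two together giving the highest numbers of the three; compound 2 lies far lower. Compound 4, `Cc1ccccc1S(=O)(=O)NCc1ccc(CNC(=O)c2cccnc2)cc1`, is not yet measured and differs from compound 1 by 2-methylphenyl in place of 4-nitrophenyl on a sulfonyl sulfur. The step of no change at the digits printed from compound 1 to compound 3 (within the scatter) shows that the amide aryl group hardly matters here, whereas a 100-fold higher number from compound 2 to compound 3 (2.00 log units; beyond the scatter) shows a large shift when the sulfonyl aryl group changes. Compound 4 carries a 2-methylphenyl on the sulfonyl sulfur, so a large drop in the number is expected, a 33-fold lower number from compound 1 to compound 4 (1.52 log units; beyond the scatter). Compound 4 is therefore estimated at 3 nM, in the range 0.5 nM to 30 nM.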

Compound 4, effective concentration (reported as EC, without a stated level of effect): 1000 nM
Compound 4: middle estimate off by 330-fold (2.52 log units), on the low side, outside the stated range (above it).
By their numbers in this assay, from the lowest: compound 2; then compounds 1 and 3 (each within the scatter of the next); then compound 4.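

With the pyridin-3-yl amide kept, 2-methylphenyl in place of 4-nitrophenyl on the sulfonyl sulfur gives a 10-fold higher number from compound 1 to compound 4 (1.00 log units; beyond the scatter) in this assay, so this position also moves the number when the amide carries pyridin-3-yl. The earlier step at this position, a 100-fold higher number from compound 2 to compound 3 (2.00 log units; beyond the scatter), showed 4-nitrophenyl raising the number, whereas here leaving 4-nitrophenyl raises it as well, so 4-nitrophenyl does not mark the high end of this position. Nothing available accounts for this shift.

Still open, as far as these compounds go, is whether 2-fluorophenyl keeps its low number with the pyridin-3-yl amide. From the compounds shown here alone, how an amine or a carboxylic acid on the sulfonyl aryl group would read also remains open.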